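The source may report more compounds than this note shows. Statements on the series, on what has been measured and on what is new or still open speak of the compounds shown alone.

Measured compounds:
Compound 1 `COCn1c(CC(COCc2ccccc2)COCc2ccccc2)c(C)c(=O)[nH]c1=O`: in a functional assay on SW-620 cells (Homo sapiens) for antiproliferative activity, read by MTT assay, with a stated time of 72 h (a lower number here means a stronger inhibitor, a higher number a weaker inhibitor), compound 1 gives 72100 nM.
Compound 2 `Cc1c(CC(O)COCc2ccccc2)n(COCC[Si](C)(C)C)c(=O)[nH]c1=O`: in this assay compound 2 gives > 100000 nM, which is a limit of the assay and not a number.

Among the measured compounds shown here, compound 2 stands at the limit of > 100000 nM in this assay, at which 1 of the 2 values shown sits; of the two values shown it is the one that is only a limit, while compound 1 is the one with a number. The change from compound 2 to compound 3 `COCn1c(CC(O)COCc2ccccc2)c(C)c(=O)[nH]c1=O` is a hydrogen atom in place of a group of 5 heavy atoms (4 carbon, 1 silicon; no ring), on a saturated chain carbon bound to an oxygen on a saturated carbon. For the measured compounds named here, no measured pair shows this change, so the data give no step to lean on. Going by the values given here, compound 1, the only compound with a number, gives 72100 nM in this assay, a weak value. Compound 3 is therefore expected to remain weak, and the expected step is an at least 1.1-fold lower number from compound 2 to compound 3 (0.04 log units; that floor lies within the scatter), staying within the scatter. Compound 3 is estimated at 90000 nM, in the range 40000 nM to 200000 nM.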

Compound 3, half-maximal inhibitory concentration: > 100000 nM
Compound 3 ended at the assay's limit; the forecaster's own chance of this, stated with the estimate: 50%; middle value at least 1.1-fold (0.04 log units) from the limit.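

In this assay, among the compounds shown here, only one step can be read: hydroxy in place of (benzyloxy)methyl, on a saturated chain carbon bound to two saturated chain carbons, gives an at least 1.3-fold higher number from compound 1 to compound 3 (0.14 log units; that floor lies within the scatter). The floor of that step lies within the scatter, so it shows no firm loss, but it also shows that hydroxy brings no measurable gain at this position. The step that removes the group of 5 heavy atoms cannot be read because both of its values are limits, and the set now rests largely at the limit: the limit of > 100000 nM in this assay, at which 2 of the 3 values shown sit.

The compounds shown leave open whether an amine or a carboxylic acid on that saturated chain carbon would give a number at all. They also leave open how large the step on removing the group of 5 heavy atoms really is.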